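Allyloxy in place of isobutoxy: compound 1 to compound 4

This account rests on a few compounds, and the source may have more. Where it says the series, first, only, none or still open, it means among the compounds named here.

Compound 1 `CC(C)COc1ccc2c(Cl)ccnc2c1` gives 2680 nM in a functional assay on RKO cells (Homo sapiens) for cytotoxicity, read by MTT assay, with a stated time of 48 h; on this read-out higher numbers stand for weaker inhibition and lower numbers for stronger inhibition. That is the highest of the three numbers measured in the series. Compound 2 `CCCCCCOc1ccc2c(NCCN(C)C)ccnc2c1` gives 1120 nM and compound 3 `CN(C)CCCNc1ccnc2cc(OCc3ccc(F)cc3)ccc12` gives 1230 nM; each stands at a lower number than compound 1 by an amount beyond the usual scatter, so compound 1 is the weakest of the three measured. Among the compounds with values here, compounds 2 and 3 both differ from compound 1 in more than one place, so no single-change step exists among the measured compounds.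

Compound 4 `C=CCOc1ccc2c(Cl)ccnc2c1` differs from compound 1 in one place: vinyl in place of isopropyl on a saturated chain carbon bound to an oxygen on an aromatic ring. Within the data shown here, no measured pair shows this change, so nothing here indicates its direction, and the working expectation is a step of no more than the usual scatter, in either direction. For compound 4 the expected step is a 1.1-fold lower number from compound 1 to compound 4 (0.03 log units; within the scatter). Compound 4 is therefore estimated at 2500 nM, with a range from 1100 nM to 5600 nM.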

Compound 4, half-maximal inhibitory concentration: 2460 nM
Estimate against measurement, compound 4: 1.0-fold (0.01 log units) above; low and high end bracket the measured number.
By their numbers in this assay, from the lowest: compounds 2, 3, 4 and 1 (each within the scatter of the next, the first and the last beyond it).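

In this assay, within the data shown here, the exchange of isobutoxy for allyloxy gives the first single-change pair of the series, with a 1.1-fold lower number from compound 1 to compound 4 (0.04 log units; within the scatter) as its step, within the scatter. At this place, on a saturated chain carbon bound to an oxygen on an aromatic ring, isopropyl with 3 heavy atoms gives way to vinyl with 2 heavy atoms and a double bond, and the read-out stays level, so this one pair shows that the chain end can take this change without a step beyond the scatter. No measurement at hand gives a reason for this outcome.

Open, going by these compounds, is whether a longer chain, a carboxylic acid or a cyclopropyl group at this chain end would leave the number level on the core of compound 1. Also open, on these data alone, is whether vinyl in place of isopropyl gives a similar step on the core of compound 2.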